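This account rests on a few compounds, and the source may have more. Where it says the series, first, only, none or still open, it means among the compounds named here.

Three compounds have been measured in a functional assay (aorta) with Rattus norvegicus as the target; on this read-out lower numbers stand for an effect already at smaller amounts and higher numbers for an effect only at larger amounts of compound:
Compound 1, `COc1ccc(-c2nc(/N=C(\N)[N+]3(C)CCCCC3)sc2-c2ccc(OC)cc2)cc1`, gives 21 uM.
Compound 2, `COc1ccc(-c2nc(CNC(=O)C3=NNC(=O)CC3)sc2-c2ccc(OC)cc2)cc1`, gives 7.3 uM.
Compound 3, `CNC(=O)NCc1nc(-c2ccc(OC)cc2)c(-c2ccc(OC)cc2)s1`, gives 15 uM.

Among these numbers compound 1 stands highest of the three; its gap to compound 3 is within the scatter, while its gap to compound 2 lies beyond it.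

Compound 4, `COc1ccc(-c2nc(C(=O)N(C)C)sc2-c2ccc(OC)cc2)cc1`, has not yet been measured. It differs from compound 1 in one place: a group of 5 heavy atoms (3 carbon, 1 nitrogen, 1 oxygen; no ring) in place of a group of 10 heavy atoms (7 carbon, 3 nitrogen; one six-membered non-aromatic ring with 1 hetero atom), on an aromatic carbon. The shared core and both 4-methoxyphenyl groups remain unchanged.

For the measured compounds named here, one measured step bears directly on this change. The step from compound 1 to compound 3 also swaps the same ring-containing group of 10 heavy atoms for a small acyclic group on the same aromatic carbon, and it gave a 1.4-fold lower number from compound 1 to compound 3 (0.15 log units; within the scatter). The other step, a 2.1-fold higher number from compound 2 to compound 3 (0.31 log units; beyond the scatter), is a change on a carbonyl carbon and so is less comparable, but it too is modest. Removing the group with a net charge thus appears to move the number only a little. The expectation is therefore a small step down or none beyond the scatter: a 1.4-fold lower number from compound 1 to compound 4 (0.15 log units; within the scatter). Compound 4 is accordingly estimated at 15 uM, with a likely range from 5 uM to 45 uM.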

Compound 4, concentration for half-maximal effect: 3 uM
Beside the measured number, compound 4's estimate is 5.0-fold (0.70 log units) above it; the whole stated range lies above it.
By their numbers in this assay, from the lowest: compound 4; then compound 2; then compounds 3 and 1 (each within the scatter of the next).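

In this assay, the aromatic carbon next to the ring nitrogen and next to the ring sulfur now proves sensitive to what it carries, since exchanging the ring-containing group for dimethylcarbamoyl gives a 7.0-fold lower number from compound 1 to compound 4 (0.85 log units; beyond the scatter) and a clear change at this place. Losing the net charge does not by itself bring the number this low: compound 3 also carries no net charge, yet the change to dimethylcarbamoyl still gives a 5.0-fold lower number from compound 3 to compound 4 (0.70 log units; beyond the scatter) with the rest of the molecule unchanged. Nothing measured here explains why dimethylcarbamoyl does better than the other groups at this carbon.

The compounds shown leave open which part of dimethylcarbamoyl matters, the carbonyl attached directly to the ring or the two methyl groups on its nitrogen. A simple unsubstituted carboxamide, a diethylcarbamoyl group or a carboxylic acid on the same carbon would begin to separate these parts, and a plain methyl group would show how much of the effect needs a carbonyl at all.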